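The compounds below may be only part of what the source reports. "The series", "measured", "known", "first", "only" and "open" are said of these compounds alone.

Measured compounds in an assay on isolated protein for inhibition of Nicotinamide phosphoribosyltransferase (Homo sapiens), read by WST assay, with stated times of 60 min, 5 min and 30 min, in the presence of a further agent that is not named here; on this read-out lower numbers stand for stronger inhibition and higher numbers for weaker inhibition: compound 1 `O=C(/C=C/c1cccnc1)NCCCc1cccc(S(=O)(=O)Nc2ccccc2)c1` gives 235 nM; compound 2 `Cc1ccc(NS(=O)(=O)c2cccc(CCCCCCNC(=O)/C=C/c3cccnc3)c2)cc1` gives 9.78 nM; compound 3 `Cc1ccc(C)c(NS(=O)(=O)c2cccc(CCCCCCNC(=O)/C=C/c3cccnc3)c2)c1` gives 11.6 nM.

Compound 2 has the lowest number of the three; compound 3 sits within the scatter of it, and compound 1 lies a long way higher. Compound 4 `O=C(/C=C/c1cccnc1)NCCCCCCc1cccc(S(=O)(=O)Nc2ccc(Oc3ccccc3)cc2)c1` differs from compound 2 in one place: phenoxy in place of methyl on an aromatic carbon. Within the data shown here, the only single-point step on the sulfonamide aryl, a 1.2-fold higher number from compound 2 to compound 3 (0.07 log units; within the scatter), was within the scatter, so variation of that ring so far left this assay unchanged. Among the measured compounds shown here, no measured step covers a phenoxy here. On that basis a step of a 1.2-fold higher number from compound 2 to compound 4 (0.09 log units; within the scatter) is expected, no change beyond the scatter. Compound 4 is therefore estimated at 12 nM in this assay, within 4 nM to 40 nM.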

Compound 4, half-maximal inhibitory concentration: 13.1 nM
The estimate for compound 4 lay 1.1-fold (0.04 log units) below the measured number; low and high end bracket the measured number.
By their numbers in this assay, from the lowest: compounds 2, 3 and 4 (each within the scatter of the next); then compound 1.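

In this assay, phenoxy in place of methyl on the sulfonamide aryl, para to a large group, gives a 1.3-fold higher number from compound 2 to compound 4 (0.13 log units; within the scatter). This position therefore takes 7 heavy atoms, an added aromatic ring and a hydrogen-bond acceptor in place of a single methyl without a change beyond the scatter, whereas the earlier step on this ring involved only methyl groups. No evidence on hand bears on why this change leaves the number within the scatter. From the compounds shown here alone, whether an amine or a carboxylic acid at this position would do the same remains open. Also open, going by these compounds, is whether phenoxy would behave alike on the chain of compound 1.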